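Replacing 4-chlorophenyl with 3-methylphenyl

A few compounds are considered here, and "the series" means these few. Any claim that something is new, unique, unknown or untested is made for them only; others in the source may bear on it.

In a functional assay on LoVo cells (Homo sapiens) for inhibition, read by MTT assay, with a stated time of 24 h (on this read-out lower numbers stand for stronger inhibition and higher numbers for weaker inhibition), compound 1 (`CC1(C)[C@H]2CC[C@]1(C)N(Cc1cn(-c3ccc(F)cc3)nn1)C(=O)C2`) gives 40 nM and compound 2 (`CC1(C)[C@H]2CC[C@]1(C)N(Cc1cn(-c3ccc(Br)cc3)nn1)C(=O)C2`) gives 60 nM while compound 3 (`CC1(C)[C@H]2CC[C@]1(C)N(Cc1cn(-c3ccc(Cl)cc3)nn1)C(=O)C2`) gives 160 nM (the highest number of the three, so the weakest inhibition). Compound 4 (`Cc1cccc(-n2cc(CN3C(=O)C[C@@H]4CC[C@@]3(C)C4(C)C)nn2)c1`) has not been measured yet. It carries 3-methylphenyl in place of 4-chlorophenyl on an aromatic nitrogen.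

Among the compounds with values here, three measured steps touch this group: a 4.0-fold higher number from compound 1 to compound 3 (0.60 log units; beyond the scatter) and a 2.7-fold higher number from compound 2 to compound 3 (0.43 log units; beyond the scatter) and also a 1.5-fold higher number from compound 1 to compound 2 (0.18 log units; within the scatter) (the first two modest, the last one small). All three only exchange one halogen for another, so none shows what 3-methylphenyl itself does. The other two numbers both lie lower than that of compound 3 at 160 nM and so a slight drift to a lower number is expected, probably nothing beyond the scatter. In this assay the step expected is a 1.6-fold lower number from compound 3 to compound 4 (0.20 log units; within the scatter) and the uncertainty is wide. Compound 4 is estimated at 100 nM (range 35 nM to 300 nM).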

Compound 4, half-maximal inhibitory concentration: 50 nM
Compound 4: the middle estimate sits 2.0-fold (0.30 log units) above what was measured; measured number inside the range.
By their numbers in this assay, from the lowest: compounds 1, 4 and 2 (each within the scatter of the next); then compound 3.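

In this assay, the aromatic nitrogen of the five-membered ring can carry a phenyl group with no halogen on it: 3-methylphenyl in place of 4-chlorophenyl gives a 3.2-fold lower number from compound 3 to compound 4 (0.51 log units; beyond the scatter) and this step lies beyond the scatter. Against the other two halogen compounds the same exchange stays within the scatter, with a 1.2-fold lower number from compound 2 to compound 4 (0.08 log units; within the scatter) and a 1.3-fold higher number from compound 1 to compound 4 (0.10 log units; within the scatter) so compound 4 sits level with compound 1 and compound 2, and compound 3 alone stands apart. Nothing available here explains why compound 3 differs from the other three.

The change swaps both the substituent and its place on the phenyl ring, and 4-methylphenyl or 3-chlorophenyl would be needed to separate those two effects. On these data alone, whether this position also accepts a phenyl ring bearing an amine or a carboxylic acid remains open.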